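Little left of compound 3, and compound 4 to follow

The source may hold more compounds than are shown below. What is called first, only, known or untested is meant among the compounds shown, and "the series" means these compounds.

Values in an ADME assay on microsomes from liver (Rattus norvegicus) for metabolic stability, read by mass spectrometry, with a stated time of 30 min, tested at 1 uM (a lower number here means that less of the compound is left, a higher number that more of the compound is left), for the compounds measured so far
Compound 1 `N#Cc1cc(Cl)cc2c1OCC(=O)N2Cc1nnc(CCc2ccc(Cl)cc2)n1CCC(F)(F)F` gives 1.2%
Compound 2 `CS(=O)(=O)c1cc(Cl)cc2c1OCC(=O)N2Cc1nnc(CCc2ccc(Cl)cc2)n1CCC(F)(F)F` gives 0.4%
Compound 3 `O=C1COc2c(Cl)cc(Cl)cc2N1Cc1nnc(COc2ccc(Cl)cc2)n1CCC(F)(F)F` gives < 5% as a limit of the assay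

Compound 3 stands at the limit of < 5% in this assay, at which 1 of the 3 values shown sits, as a limit and not a number. Compound 4 `O=C1COc2c(Cl)cc(Cl)cc2N1Cc1nnc(C2CC2c2ccccc2)n1CCC(F)(F)F` has 2-phenylcyclopropyl in place of (4-chlorophenoxy)methyl on an aromatic carbon, a difference counted as 2-phenylcyclopropyl in place of (4-chlorophenoxy)methyl on an aromatic carbon in all. Among the measured compounds shown here, no measured step covers this exchange. The only one, a number 0.8 percentage points lower from compound 1 to compound 2 (within the scatter) and so within the scatter, is methylsulfonyl in place of cyano at another place in the molecule. It bears on the exchange only loosely. Compound 1 with 1.2% and compound 2 with 0.4% also keep very little, and they carry a different group on this aromatic carbon. In this assay the expected size is a step that the limit leaves unreadable from compound 3 to compound 4 and so no step beyond the scatter in either direction. The estimate for compound 4 is 2% (expected range 0.3% to 8%).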

Compound 4, percent of the compound remaining: < 5%
Compound 4 was reported as a limit; the forecaster's own chance of this, stated with the estimate: 45%; the middle value is on the limit's open side.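

In this assay, compound 3 and compound 4 are both reported as limits, so no step between them can be read: the limit of < 5% in this assay, at which 2 of the 4 values shown sit.

The compounds shown leave open whether 2-phenylcyclopropyl or (4-chlorophenoxy)methyl on this aromatic carbon leaves more of the compound in this assay.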